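The source may hold more compounds than are shown below. What is called first, only, known or untested is meant among the compounds shown, and "the series" means these compounds.

Compound 1, `COc1cccc(C(=O)Oc2ccc3c(=O)c(-c4cc(OC)c(OC)cc4OC)coc3c2)c1`, and compound 2, `COc1cc(OC)c(-c2coc3cc(OCC(=O)c4cccc(C(F)(F)F)c4)ccc3c2=O)cc1OC`, share one core and were both tested in a functional assay on A-375 cells (Homo sapiens) for antiproliferative activity, read by MTT assay, with a stated time of 24 h; a lower number here means a stronger inhibitor, a higher number a weaker inhibitor. In this assay compound 1 gives only a limit, > 10000 nM. Compound 2 also reaches only a limit in this assay, > 10000 nM. Both results sit at the limit of > 10000 nM in this assay, at which 2 of the 2 values shown sit, so compound 2 is not separated from compound 1 by any measured step. Compound 3, `COc1cc(OC)c(-c2coc3cc(OCc4ccc(C(F)(F)F)cc4)ccc3c2=O)cc1OC`, differs from compound 2 in a single place: 4-(trifluoromethyl)phenyl in place of (3-(trifluoromethyl)phenyl)carbonyl on a saturated chain carbon bound to an oxygen on an aromatic ring. Within the data shown here, no measured step of this kind exists. The step that the limit leaves unreadable from compound 2 to compound 3 is expected to stay within the scatter. Compound 3 is therefore estimated at 15000 nM, between 3000 nM and 60000 nM.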

Compound 3, half-maximal inhibitory concentration: 2280 nM
The estimate for compound 3 lay 6.6-fold (0.82 log units) above the measured number, outside the stated range (below it).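

In this assay, compound 3 alone among the three gives a number rather than a limit, so this position can carry a measurable response: the limit of > 10000 nM in this assay, at which 2 of the 3 values shown sit. 4-(Trifluoromethyl)phenyl in place of (3-(trifluoromethyl)phenyl)carbonyl gives an at least 4.3-fold lower number from compound 2 to compound 3 (0.64 log units; beyond the scatter). 4-(Trifluoromethyl)benzyl in place of (3-methoxyphenyl)carbonyl gives an at least 4.3-fold lower number from compound 1 to compound 3 (0.64 log units; beyond the scatter).

The compounds shown do not separate the loss of the carbonyl from the different placing of the trifluoromethyl. Also open, as far as these compounds go, is how an amine or a carboxylic acid in place of the trifluoromethyl, or a longer chain, would read.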